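From 3-methylphenyl to 2-isopropylphenyl on the shared core

This account rests on a few compounds, and the source may have more. Where it says the series, first, only, none or still open, it means among the compounds named here.

In a functional assay on MDA-MB-231 cells (Homo sapiens) for inhibition, read by CCK-8 assay, with a stated time of 48 h (on this read-out higher numbers stand for weaker inhibition of growth and lower numbers for stronger inhibition of growth), compound 3 `Cc1cccc(Nc2nc(Nc3ccc(N4CCN(C)CC4)cn3)ncc2Cl)c1` gives 5270 nM, the second highest of three numbers. Compound 2 `Cc1ccc(Nc2nc(Nc3ccc(N4CCN(C)CC4)cn3)ncc2Cl)cc1` gives 4030 nM, and compound 1 `COc1ccccc1CNc1nc(Nc2ccc(N3CCN(C)CC3)cn2)ncc1Cl` gives 29300 nM. Compound 4 `CC(C)c1ccccc1Nc1nc(Nc2ccc(N3CCN(C)CC3)cn2)ncc1Cl` carries 2-isopropylphenyl in place of 3-methylphenyl on a nitrogen on an aromatic ring. Among the measured steps, 3-methylphenyl in place of 4-methylphenyl gave a 1.3-fold higher number from compound 2 to compound 3 (0.12 log units; within the scatter), within the scatter. Replacing 2-methoxybenzyl gave modest steps: a 7.3-fold lower number from compound 1 to compound 2 (0.86 log units; beyond the scatter) and a 5.6-fold lower number from compound 1 to compound 3 (0.75 log units; beyond the scatter). Compound 4 remains a substituted phenyl, so the closest guide is a 1.3-fold higher number from compound 2 to compound 3 (0.12 log units; within the scatter), and no step beyond the scatter is expected in this assay. The estimated step is a 1.2-fold lower number from compound 3 to compound 4 (0.07 log units; within the scatter). The estimate for compound 4 is 4500 nM, with an expected range of 1500 nM to 13000 nM.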

Compound 4, concentration for 50% growth inhibition: 4090 nM
Compound 4: middle estimate off by 1.1-fold (0.04 log units), on the high side; low and high end bracket the measured number.
By their numbers in this assay, from the lowest: compounds 2, 4 and 3 (each within the scatter of the next); then compound 1.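

In this assay, the larger 2-isopropylphenyl group leaves the number within the scatter of both smaller aryl groups (a 1.3-fold lower number from compound 3 to compound 4 (0.11 log units; within the scatter) and a 1.0-fold higher number from compound 2 to compound 4 (0.01 log units; within the scatter)), so this position accepts the added carbons without a readable change among compound 2, compound 3 and compound 4. The gap to the 2-methoxybenzyl group persists with this new group (a 7.2-fold lower number from compound 1 to compound 4 (0.86 log units; beyond the scatter)). No measurement in hand speaks to the reason for either result. Still open, on these data alone, is whether an amine or a carboxylic acid on the phenyl ring would shift the number, and whether an unsubstituted benzyl group would match compound 1.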